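From compound 1 to compound 4: an exchange without a baseline

The source may hold more compounds than are shown below. What is called first, only, known or untested is meant among the compounds shown, and "the series" means these compounds.

In a physicochemical assay for permeability, using PAMPA (a higher number here means that the compound crosses the layer faster, a lower number that the compound crosses the layer more slowly), compound 1 `Cc1ccc(C)c(-c2nc(CN3CCC(C(=O)NCCCN4C[C@H](C)C[C@H](C)C4)CC3)c(C)o2)c1` stands at "not determined" (no result reported) and so offers no number to start from. Compound 4 `Cc1oc(-c2c(F)cccc2F)nc1CN1CCC(C(=O)NCCCN2C[C@H](C)C[C@H](C)C2)CC1` differs from compound 1 by a single exchange: 2,6-difluorophenyl in place of 2,5-dimethylphenyl on an aromatic carbon is the whole change, and the rest of the structure stays as it is. In words, 2,6-difluorophenyl replaces 2,5-dimethylphenyl on an aromatic carbon of a five-membered aromatic ring with 1 nitrogen and 1 oxygen.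

For the measured compounds named here, only one measured step is available. Hydrogen in place of isopropyl on a saturated ring carbon gives an 11-fold lower number from compound 2 to compound 3 (1.06 log units; beyond the scatter) as that step, with compound 2 `Cc1ccccc1-c1nc(CN2CCC(C(=O)NCCCN3CCC(C(C)C)CC3)CC2)c(C)o1` and compound 3 `Cc1ccccc1-c1nc(CN2CCC(C(=O)NCCCN3CCCCC3)CC2)c(C)o1` as its two ends. It lies at a different place from the present exchange, so it shows only how far the numbers in this small set can move with one change. Going by the values given here, no measured step touches the group on the aromatic carbon, and no size or direction can be assigned to the change at hand. The expectation therefore rests on the span from compound 3 at 34.5 10^-6 cm/s to compound 2 at 396 10^-6 cm/s and stays wide. For compound 4 the expected value is 120 10^-6 cm/s within an estimated range of 30 10^-6 cm/s to 400 10^-6 cm/s in this assay.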

Compound 4, apparent permeability: 82.4 10^-6 cm/s
For compound 4 the middle estimate is 1.5-fold (0.16 log units) above the measured one; measured number inside the range.
By their numbers in this assay, from the lowest: compound 3; then compound 4; then compound 2.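

No new step can be read between compound 1 and compound 4: in this assay compound 4 at 82.4 10^-6 cm/s has no number from compound 1 to pair with. On these data alone, the effect of 2,6-difluorophenyl in place of 2,5-dimethylphenyl on this assay remains open, in both size and direction. Nothing at hand offers an explanation for the value of compound 4.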